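From Acid to Pentyl Amide: An Expected Step

This account rests on a few compounds, and the source may have more. Where it says the series, first, only, none or still open, it means among the compounds named here.

Compound 1, `COc1cc2c(cc1OC)C(CC(=O)O)CC2`, is the reference point of this account. In a functional assay on the whole organism (strain Swiss albino) for inhibition, with Mus musculus as the target, in the writhing test, with stated times of 60 min and 15 min, at a dose of 100 mg/kg by the oral route (a higher number here means more inhibition at the dose given (going by the name of the read-out), a lower number less inhibition), compound 1 gives 44%. For the measured compounds named here, its only measured neighbour is compound 2, `CCCCNC(=O)CC1CCc2cc(OC)c(OC)cc21`, which in this assay gives 39.4%. The two numbers lie within the scatter of each other, so neither compound is set apart by them. Going by the values given here, the one step between measured compounds, a number 4.6 percentage points lower from compound 1 to compound 2 (within the scatter), comes from butylamino in place of hydroxy on a carbonyl carbon and does not exceed the scatter.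

The compound now in question is compound 3, `CCCCCNC(=O)CC1CCc2cc(OC)c(OC)cc21`. It differs from compound 1 by pentylamino in place of hydroxy on a carbonyl carbon. This change is a close relative of the measured step: a pentylamino group rather than the butylamino of compound 2 enters at the same carbonyl carbon. Because a number 4.6 percentage points lower from compound 1 to compound 2 (within the scatter) was small, no step beyond the scatter is expected for compound 3 either, with at most a slight drift downward. Compound 3 is therefore expected to give 40%, in the range 28% to 52%. The step this estimate implies for compound 3 is a number 4 percentage points lower from compound 1 to compound 3 (within the scatter), expected to stay within the scatter.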

Compound 3, a percentage reported as inhibition, in the whole organism at one dose (the size of the read-out at that dose, not a potency): 71.7%
The estimate for compound 3 lay 31.7 percentage points below the measured number; the whole stated range lies below it.
By their numbers in this assay, from the lowest: compounds 2 and 1 (each within the scatter of the next); then compound 3.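

In this assay the carbonyl carbon proves to be a place where the number can move beyond the scatter, since pentylamino in place of hydroxy gives a number 27.7 percentage points higher from compound 1 to compound 3 (beyond the scatter), a shift that the butylamino amide, compound 2, had not shown. The sharper finding lies in the chain itself: methyl in place of hydrogen on a saturated chain carbon, four bonds along the chain from an amide-type nitrogen, gives a number 32.3 percentage points higher from compound 2 to compound 3 (beyond the scatter), so among these three compounds the change from acid to amide does not carry the rise alone, and the rise appears only with the pentylamino group. Nothing available bears on what lies behind this jump at so small a change in the chain.

As far as these compounds go, whether a hexylamino group or a still longer chain on the same carbonyl carbon would hold, raise or lose this level stays open, as does the place of a propylamino group below the butylamino of compound 2. Also open, from the compounds shown here alone, is whether a branched chain of the same size, such as isopentylamino, would behave like the straight pentylamino group, and with a single dose behind each number, the potency of compound 3 remains unknown.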